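A few compounds are considered here, and "the series" means these few. Any claim that something is new, unique, unknown or untested is made for them only; others in the source may bear on it.

Measured so far:
Compound 1 `CC1=C(C(=O)OCc2ccccc2)C(c2cccs2)NC(=O)N1` — in an assay on membranes from CHO cells for displacement of a labelled ligand from adenosine receptor A1 (Homo sapiens), read by scintillation counting, with a stated time of 60 min, tested at 1 uM (on this read-out lower numbers stand for less inhibition and higher numbers for more inhibition at the one concentration tested (going by the name of the read-out)), compound 1 gives 45%.
Compound 2 `CCC(CC)OC(=O)C1=C(C)NC(=O)NC1c1cccs1` — in this assay compound 2 gives 13%.

Among the measured compounds shown here, compound 2 stands at the lower of the two numbers; the only neighbouring measurement is compound 1, and the step of a number 32 percentage points lower from compound 1 to compound 2 (beyond the scatter) was large. Compound 3 `CC1=C(C(=O)OCC2CCC2)C(c2cccs2)NC(=O)N1` differs from compound 2 in one place: cyclobutylmethyl in place of pentan-3-yl on an oxygen next to a carbonyl group. For the measured compounds named here, the one measured step that bears on this position is a number 32 percentage points lower from compound 1 to compound 2 (beyond the scatter), where a benzyl group was exchanged for pentan-3-yl; it shows that the group on this oxygen can move the number strongly. Going by the values given here, no measured step compares two non-aromatic groups of the same size here, so the direction of the change from pentan-3-yl to cyclobutylmethyl cannot be read from the two values. The step of a number 7 percentage points higher from compound 2 to compound 3 (within the scatter) is therefore expected to be small, possibly within the scatter. Compound 3 is estimated at 20%, with a range from 5% to 40%.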

Compound 3, a percentage reported as inhibition, at one concentration (the size of the read-out at that concentration, not a potency): 39%
Compound 3: middle estimate off by 19 percentage points, on the low side; measured number inside the range.
By their numbers in this assay, from the lowest: compound 2; then compounds 3 and 1 (each within the scatter of the next).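

Pentan-3-yl and cyclobutylmethyl have the same count of heavy atoms, yet in this assay the exchange at this oxygen gives a number 26 percentage points higher from compound 2 to compound 3 (beyond the scatter), so that count alone does not fix the number. Placing cyclobutyl in place of phenyl on the saturated chain carbon gives a number 6 percentage points lower from compound 1 to compound 3 (within the scatter), which shows that, among these compounds, an aromatic ring at this spot is not needed for a number of this size. Nothing measured here explains either step.

The compounds shown do not separate the effect of the ring in cyclobutylmethyl from that of the branch point in pentan-3-yl. On these data alone, it also remains open where a straight pentyl chain, a cyclopentylmethyl group or a chain ending in an amine would fall on this oxygen.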